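Dropping One Chlorine from the Aryl Sulfone

The source may hold more compounds than are shown below. What is called first, only, known or untested is meant among the compounds shown, and "the series" means these compounds.

Among the measured compounds shown here, compound 1 `CC1CCN(c2c(S(=O)(=O)c3ccc(Cl)c(Cl)c3)cnc3ccc(Cl)cc23)CC1` gives 55.6 nM in an assay on isolated protein for displacement of a labelled ligand from metabotropic glutamate receptor 5 (Homo sapiens), with a stated time of 60 min (on this read-out higher numbers stand for weaker inhibition and lower numbers for stronger inhibition), the lowest of the two numbers measured so far; its nearest neighbour is compound 2 `CC1CCN(c2c(S(=O)(=O)c3ccc(Cl)c(Cl)c3)cnc3ccc(F)cc23)CC1`, which in this assay gives 68.2 nM. For the measured compounds named here, the one measured step, a 1.2-fold higher number from compound 1 to compound 2 (0.09 log units; within the scatter), lies within the scatter and concerns a different place, on the shared core rather than on the sulfone aryl ring. Compound 3 `CC1CCN(c2c(S(=O)(=O)c3ccc(Cl)cc3)cnc3ccc(Cl)cc23)CC1` differs from compound 1 by hydrogen in place of chloro on an aromatic carbon; read one bond further out, the 3,4-dichlorophenyl becomes 4-chlorophenyl. Going by the values given here, no measured step touches this ring, so the expectation rests on the structural change alone and carries wide uncertainty. A step of modest size toward a higher number is expected, a 2.0-fold higher number from compound 1 to compound 3 (0.30 log units; within the scatter). Compound 3 is therefore estimated at about 110 nM, with a range from 40 nM to 350 nM.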

Compound 3, inhibition constant: 435 nM
Compound 3: the middle estimate sits 4.0-fold (0.60 log units) below what was measured; measured number outside the range, above it.
By their numbers in this assay, from the lowest: compounds 1 and 2 (each within the scatter of the next); then compound 3.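

Taking 3,4-dichlorophenyl to 4-chlorophenyl gives a 7.8-fold higher number from compound 1 to compound 3 (0.89 log units; beyond the scatter) in this assay and is the only step shown that lies beyond the scatter. The exchange on the shared core, a 1.2-fold higher number from compound 1 to compound 2 (0.09 log units; within the scatter) as printed, stays within the scatter, so among these compounds only the loss of the chloro group on the sulfone aryl ring separates one number clearly from another. Nothing measured here accounts for the size of this step.

The compounds shown leave open whether another group in this place, such as methoxy or a nitrile, would give a number closer to that of compound 1, and whether removing the remaining chloro group would matter as much. Also open, on these data alone, is whether the same change on the fluoro-bearing core of compound 2 would give a step of similar size.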